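Clearance Expected for a Difluorophenyl Piperazine Analogue

A few compounds are considered here, and "the series" means these few. Any claim that something is new, unique, unknown or untested is made for them only; others in the source may bear on it.

Compounds in an ADME assay on the whole organism (Rattus norvegicus, strain Sprague-Dawley) for pharmacokinetics, using cassette dosing, at a dose of 0.5 mg/kg by the intravenous route (on this read-out lower numbers stand for slow clearance and higher numbers for fast clearance), so far:
- compound 1 (`O=C(Nc1ccc2[nH]c(=O)oc2c1)C(=O)N1CCN(c2ccc(F)cc2)CC1`) gives 11.1 mL/min/kg
- compound 2 (`COc1ccc(N2CCN(C(=O)C(=O)Nc3ccc4[nH]c(=O)oc4c3)CC2)cc1`) gives "not determined" (no result reported)
- compound 3 (`O=C(Nc1ccc2[nH]c(=O)oc2c1)C(=O)N1CCN(c2ccc(F)c(F)c2)CC1`) awaits measurement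

Compound 2 has no single number in this assay and so offers no clearance to start from. The structural change is 3,4-difluorophenyl in place of 4-methoxyphenyl on an amine nitrogen in a ring and consists of 3,4-difluorophenyl in place of 4-methoxyphenyl on an amine nitrogen in a ring. For the measured compounds named here, no measured step shows what such a change does. Going by the values given here, the only anchor is compound 1 at 11.1 mL/min/kg, and compound 3 is expected to differ from that value by no more than the usual scatter. Compound 3 is estimated at 11 mL/min/kg (expected range 5.5 mL/min/kg to 22 mL/min/kg).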

Compound 3, clearance: 4 mL/min/kg
Estimate against measurement, compound 3: 2.8-fold (0.44 log units) above; measured number below the stated range.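

In this assay, fluoro in place of hydrogen on an aromatic carbon of the group on the ring amine nitrogen gives a 2.8-fold lower number from compound 1 to compound 3 (0.44 log units; beyond the scatter), the first readable sign that clearance responds to a change at this position. The step from compound 2 to compound 3 cannot be read, since compound 2 has no number. Nothing available bears on why clearance moved.

Going by these compounds, whether the shift is specific to fluoro stays open. A chloro or nitrile on the phenyl ring could move clearance as far, less, or further.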